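This account rests on a few compounds, and the source may have more. Where it says the series, first, only, none or still open, it means among the compounds named here.

Compound 1 `COc1ccc(C2=C(c3cc(OC)c(OC)c(OC)c3)C(=O)C(OC(C)=O)C2)cc1` and compound 2 `COc1ccc(C2=C(c3cc(OC)c(OC)c(OC)c3)C(=O)C(O)C2)cc1` share one core, while compound 3 `CC(=O)OC1C/C(=N/O)C(c2ccccc2)=C1c1ccccc1` and the not yet measured compound 4 `O/N=C1/CC(O)C(c2ccccc2)=C1c1ccccc1` share another; the difference between the two cores is not broken down here. All were tested in an ADME assay on MIA PaCa-2 cells (Homo sapiens) for cytotoxicity, read by MTT assay, with a stated time of 72 h; on this read-out higher numbers stand for weaker inhibition and lower numbers for stronger inhibition. In this assay compound 1 gives only a limit, < 1 ug/mL. Compound 2 likewise gives only a limit, < 1 ug/mL. Among the measured compounds shown here, compound 3 gives a number, 4.5 ug/mL, and is the only compound with one. The change from compound 1 to compound 2 is hydrogen in place of acetyl on an oxygen on a saturated carbon, and its step is a step that the two limits leave unreadable from compound 1 to compound 2, because the limit of < 1 ug/mL in this assay, at which 2 of the 3 values shown sit, hides any movement. The change from compound 3 to compound 4 is the same, (hydrogen in place of acetyl on an oxygen on a saturated carbon), at the same place. Since the measured pair offers no readable size for this change, compound 4 is expected to land close to compound 3, with an estimated step of a 1.3-fold lower number from compound 3 to compound 4 (0.11 log units; within the scatter). Compound 4 is therefore estimated at 3.5 ug/mL, expected to lie between 1.2 ug/mL and 10 ug/mL.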

Compound 4, half-maximal inhibitory concentration: > 100 ug/mL
Compound 4 was reported as a limit (the forecaster's own chance of this, stated with the estimate: 12%); middle value at least 28-fold (1.45 log units) from the limit.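

On the core of compound 3, the change from acetoxy to hydroxy gives an at least 22-fold higher number from compound 3 to compound 4 (1.34 log units; beyond the scatter) in this assay, so on this core, removing the acetyl costs a large part of the inhibition. The value of compound 4, > 100 ug/mL, is a limit and not a number. The same change from compound 1 to compound 2 cannot be read, so the data do not show whether this loss also occurs on the other core or belongs to the core of compound 3 alone, and a single readable pair sets no general rule: the limit of < 1 ug/mL in this assay, at which 2 of the 4 values shown sit.

Among the compounds shown, this oxygen carries only acetyl or hydrogen, which leaves open whether the inhibition of compound 3 depends on the acetyl specifically or would persist with another group there. A methyl group or a longer acyl chain such as butanoyl on that oxygen remains an open case on both cores.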